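Benzimidazolyl terphenyls: trifluoromethoxy to hydroxy at the far end

The source may hold more compounds than are shown below. What is called first, only, known or untested is meant among the compounds shown, and "the series" means these compounds.

Measured so far:
- compound 1 `Oc1cccc2[nH]c(-c3ccc(-c4ccc(-c5ccc(OC(F)(F)F)cc5)cc4)cc3)nc12`: 2900 nM
- compound 2 `Oc1ccc(-c2ccc(-c3ccc(-c4nc5c(O)cccc5[nH]4)cc3)cc2)cc1`: 2920 nM
- compound 3 `Cc1ccc2[nH]c(-c3ccc(-c4ccc(-c5ccc(OC(F)(F)F)cc5)cc4)cc3)nc2c1`: 12300 nM

Compounds 1 and 2 share one core and differ only at the far phenyl ring, (hydrogen in place of trifluoromethyl on an oxygen on an aromatic ring). In a functional assay on A2780 cells (Homo sapiens) for inhibition, read by sulforhodamine B assay (on this read-out lower numbers stand for stronger inhibition of growth and higher numbers for weaker inhibition of growth), this change gave a 1.0-fold higher number from compound 1 to compound 2 (0.00 log units; within the scatter), so the trifluoromethyl on that oxygen makes no difference that can be told from repeat measurement on this pair.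

Compound 3 carries the other core; the two cores differ as 5-methyl-1H-benzimidazol-2-yl in place of 4-hydroxy-1H-benzimidazol-2-yl on an aromatic carbon. In this assay that exchange gave a 4.2-fold higher number from compound 1 to compound 3 (0.63 log units; beyond the scatter), and compound 3 stands with the highest number of the three, beyond the scatter of both compound 1 and compound 2.

Compound 4 `Cc1ccc2[nH]c(-c3ccc(-c4ccc(-c5ccc(O)cc5)cc4)cc3)nc2c1` is not yet measured. It relates to compound 3 as compound 2 relates to compound 1: hydrogen in place of trifluoromethyl on an oxygen on an aromatic ring. The place of the change is the same in both pairs, so this is the same change made on the other core.

For compound 4 in this assay the expected step is a 1.0-fold lower number from compound 3 to compound 4 (0.01 log units; within the scatter), set beside the earlier 1.0-fold higher number from compound 1 to compound 2 (0.00 log units; within the scatter); this rests on compound 1 and compound 2 giving the same number within scatter after the same change. Among the measured compounds shown here, only one such pair is known, and the core of compound 3 has not been tested with this change before, so the range is kept wide. The estimate for compound 4 is 12000 nM, between 5000 nM and 30000 nM.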

Compound 4, concentration for 50% growth inhibition: 31200 nM
Estimate against measurement, compound 4: 2.6-fold (0.41 log units) below; the measured number lies above the stated range.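

In this assay, the exchange of trifluoromethoxy for hydroxy on the core of compound 3 gave a 2.5-fold higher number from compound 3 to compound 4 (0.40 log units; beyond the scatter), a step beyond the scatter, whereas the same exchange on the other core left the number within the scatter. Even so, the two steps cannot be told apart, and the difference between the cores in this respect is not established: the same change on two cores in this assay, a 1.0-fold higher number (0.00 log units; within the scatter) from compound 1 to compound 2 and a 2.5-fold higher number (0.40 log units; beyond the scatter) from compound 3 to compound 4, 2.5-fold (0.40 log units) apart, within the scatter of two such steps
The two pairs therefore fit a change that carries over from one core to the other with a similar size, but they do not show that its size is the same on both cores or that it depends on the core, and two pairs cannot establish a rule for the series.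

Going by these compounds, only trifluoromethoxy and hydroxy appear at this place, so it remains open how a methoxy group, an amine or a carboxylic acid there would read in this assay on either core. The core is also varied only between the 4-hydroxy and 5-methyl forms, which leaves open whether an amine or a longer chain in place of the methyl would keep the numbers of these pairs or shift them.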